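A Chloro to Fluoro Swap on a Shared Core

This account rests on a few compounds, and the source may have more. Where it says the series, first, only, none or still open, it means among the compounds named here.

Of the compounds shown here, three built on a shared core have been measured so far in a functional assay on MCF7 cells (Homo sapiens) for inhibition; a higher number here means a weaker inhibitor, a lower number a stronger inhibitor. Here compound 1 `O=C1O/C(=C\Cn2cc(C(F)(F)F)c(=O)[nH]c2=O)C(OCc2ccccc2)=C1OCc1ccccc1` gives 40000 nM, and compound 2 `O=C1O/C(=C\Cn2cc(Cl)c(=O)[nH]c2=O)C(OCc2ccccc2)=C1OCc1ccccc1` gives 60000 nM. These two values lie within the scatter of each other, so compound 2 cannot be ranked apart from compound 1. Compound 3 `O=C1O/C(=C\Cn2cnc3c(-n4cccc4)ncnc32)C(OCc2ccccc2)=C1OCc1ccccc1` gives only a limit rather than a number, > 100000 nM.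

Compound 4 `O=C1O/C(=C\Cn2cc(F)c(=O)[nH]c2=O)C(OCc2ccccc2)=C1OCc1ccccc1` has not yet been measured. It differs from compound 2 in one place: fluoro in place of chloro on an aromatic carbon. In words, this is fluoro in place of chloro on an aromatic carbon.

Going by the values given here, only one measured step also exchanges one group for another on an aromatic carbon. That step is a 1.5-fold higher number from compound 1 to compound 2 (0.18 log units; within the scatter), with chloro in place of trifluoromethyl, and it stays within the scatter. A single step is thin evidence, but it gives no reason to expect a change beyond the scatter in this assay. The expected step is therefore small and is estimated as a 1.3-fold lower number from compound 2 to compound 4 (0.12 log units; within the scatter). For compound 4 the estimated value is 45000 nM, with an expected range from 18000 nM to 100000 nM.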

Compound 4, half-maximal inhibitory concentration: 60000 nM
For compound 4 the middle estimate is 1.3-fold (0.12 log units) below the measured one, within the range that was stated.
By their numbers in this assay, from the lowest: compounds 1, 2 and 4 (each within the scatter of the next). At a limit, above all of these: compound 3.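

On this aromatic carbon of the six-membered aromatic ring with 2 nitrogen, swapping chloro for fluoro has no readable effect in this assay: the result is no change at the digits printed from compound 2 to compound 4 (within the scatter). The same carbon now also offers a second comparison, a 1.5-fold higher number from compound 1 to compound 4 (0.18 log units; within the scatter), so trifluoromethyl, chloro and fluoro all lie within the scatter of one another, and the lack of a clear difference at this position no longer rests on a single step. Compound 3 alone remains a limit rather than a number, and it differs from the others in more than one place, so it adds nothing to this comparison: the limit of > 100000 nM in this assay, at which 1 of the 4 values shown sits.

On these data alone, whether this position would respond to a different kind of group, such as an amine, a carboxylic acid, a nitrile or a longer chain, remains open, since the three groups compared here give no step beyond the scatter to build on. Also open, as far as these compounds go, is whether trifluoromethyl, chloro and fluoro would stay this close together on another core or in another assay.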